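A Chain Rearrangement Tested Against Leukaemia Cells

A few compounds are considered here, and "the series" means these few. Any claim that something is new, unique, unknown or untested is made for them only; others in the source may bear on it.

Compound 1 `COC[C@H](C)[C@@H](C)C(c1ccc(O)c(OC)c1)c1ccc(O)c(OC)c1` carries a 2-(methoxymethyl)-1-methylpropyl group on a saturated chain carbon bound to two aromatic carbons. In a functional assay on HL-60 cells (Homo sapiens) for cytotoxicity, read by WST assay, with a stated time of 48 h (on this read-out higher numbers stand for weaker inhibition and lower numbers for stronger inhibition), compound 1 gives 68000 nM. Compound 2 `COc1cc(C(c2ccc(O)c(OC)c2)[C@@H](C)[C@H](C)CO)ccc1O` differs from it by having 2-(hydroxymethyl)-1-methylpropyl in place of 2-(methoxymethyl)-1-methylpropyl on a saturated chain carbon bound to two aromatic carbons. In this assay compound 2 reaches only the limit of the assay, > 100000 nM. The step is an at least 1.4-fold higher number from compound 1 to compound 2 (0.16 log units; that floor lies within the scatter). Compound 3 `COc1ccc(C(c2ccc(OC)c(OC)c2)[C@@H](C)[C@@H](C)CO)cc1OC` likewise reaches only the limit, giving > 100000 nM in this assay. Compound 2 therefore stands at the limit of > 100000 nM in this assay, at which 2 of the 3 values shown sit, with no number of its own.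

Compound 4 `COc1cc(C(c2ccc(O)c(OC)c2)[C@H](CO)C(C)C)ccc1O` is an isomer of compound 2: 1-(hydroxymethyl)-2-methylpropyl in place of 2-(hydroxymethyl)-1-methylpropyl on a saturated chain carbon bound to two aromatic carbons. Among the compounds with values here, only the step from compound 1 to compound 2 bears on this change, and it shows that altering this chain from compound 1 left the number at or beyond the limit. Within the data shown here, no measured step touches the entering chain, so no movement beyond the scatter is expected, and compound 4 is expected to sit near the limit, with a step that the limit leaves unreadable from compound 2 to compound 4 expected. Compound 4 is estimated to give 150000 nM, between 50000 nM and 500000 nM.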

Compound 4, half-maximal inhibitory concentration: > 100000 nM
Compound 4: a limit, no number (the forecaster's own chance of this, stated with the estimate: 75%); the middle value does not contradict the limit.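

Moving the branch, so that 1-(hydroxymethyl)-2-methylpropyl replaces 2-(hydroxymethyl)-1-methylpropyl on a saturated chain carbon bound to two aromatic carbons, still gives no number: in this assay compound 4 gives > 100000 nM, which is a limit of the assay. Both compound 2 and compound 4 are limits, so the step that joins them cannot be read, and this rearrangement of the chain can be neither called silent nor given a size. Set against the methoxymethyl chain, the new chain gives an at least 1.4-fold higher number from compound 1 to compound 4 (0.16 log units; that floor lies within the scatter), so compound 4 is not shown to differ from compound 1 beyond the scatter, while the series gathers further at its limit: the limit of > 100000 nM in this assay, at which 3 of the 4 values shown sit.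

The compounds shown leave open how far past the limit compound 2 and compound 4 lie, so the two isomers cannot be ordered against each other. They also leave open whether a chain ending in an amine or a carboxylic acid in place of the hydroxymethyl end, or a longer chain, on this saturated chain carbon would give a number of its own in this assay.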